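Thiazol-2-yl amide on the shared core: expected edema inhibition

This account rests on a few compounds, and the source may have more. Where it says the series, first, only, none or still open, it means among the compounds named here.

Three compounds built on one shared core differ only in the group on the amide-type nitrogen. Compound 1 `O=C(NN1CCOCC1)c1c(O)c2cccnc2n(-c2ccccc2)c1=O` carries a morpholin-4-yl there and, in a functional assay on the whole organism for inhibition, with Rattus norvegicus as the target, read by paw edema, at a dose of 100 mg/kg by the oral route (on this read-out higher numbers stand for more inhibition at the one dose given (going by the name of the read-out) and lower numbers for less inhibition), compound 1 gives -8.5%, the lowest of the three numbers. Compound 2 `Cc1cccc(NC(=O)c2c(O)c3cccnc3n(-c3ccccc3)c2=O)c1` gives 14.2% in this assay, and compound 3 `O=C(Nc1ccncc1)c1c(O)c2cccnc2n(-c2ccccc2)c1=O` gives 34.9%.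

The two steps away from compound 1 both run upward: a number 22.7 percentage points higher from compound 1 to compound 2 (beyond the scatter) with 3-methylphenyl in place of morpholin-4-yl, and a number 43.4 percentage points higher from compound 1 to compound 3 (beyond the scatter) with pyridin-4-yl in place of morpholin-4-yl. Between the two aromatic groups, a number 20.7 percentage points higher from compound 2 to compound 3 (beyond the scatter).

Compound 4 `O=C(Nc1nccs1)c1c(O)c2cccnc2n(-c2ccccc2)c1=O` is the next case. Its difference from compound 1 is 1,3-thiazol-2-yl in place of morpholin-4-yl on an amide-type nitrogen. As in the steps to compound 2 and compound 3, the morpholin-4-yl gives way to an aromatic ring, here a five-membered one with 2 hetero atoms, one of them nitrogen as in pyridin-4-yl. Both earlier replacements raised inhibition beyond the scatter, by a modest and by a large amount, so a rise of similar order is expected, without grounds to choose precisely between them.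

Compound 4 is therefore expected to reach 30%, within 5% to 52%, an estimated a number 38.5 percentage points higher from compound 1 to compound 4 (beyond the scatter).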

Compound 4, a percentage reported as inhibition, in the whole organism at one dose (the size of the read-out at that dose, not a potency): 4.6%
Compound 4: middle estimate off by 25.4 percentage points, on the high side, outside the stated range (below it).
By their numbers in this assay, from the lowest: compound 1; then compounds 4 and 2 (each within the scatter of the next); then compound 3.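

In this assay, the rise seen on replacing morpholin-4-yl with an aromatic ring holds for a third ring, a number 13.1 percentage points higher from compound 1 to compound 4 (beyond the scatter), so all three aromatic groups on the amide-type nitrogen now stand above the morpholine compound. The size of that rise, however, depends on which ring enters: a ring nitrogen in an aromatic ring does not by itself bring the level reached with pyridin-4-yl, as the five-membered 1,3-thiazol-2-yl shows with a number 30.3 percentage points lower from compound 3 to compound 4 (beyond the scatter). The thiazole also cannot be told apart from the 3-methylphenyl group, which has no ring nitrogen, at a number 9.6 percentage points lower from compound 2 to compound 4 (within the scatter), so pyridin-4-yl is the only one of the three aromatic groups that stands clear of the other two.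

No measurement offered here explains why the pyridin-4-yl compound stands apart from the other two aromatic compounds. Still open, going by these compounds, is how a pyridin-3-yl, a plain phenyl or a 1,3-oxazol-2-yl on the same nitrogen would read in this assay, and so whether the high number of compound 3 belongs to pyridin-4-yl alone or extends to close relatives of it.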